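Trimming One Methoxy Group from a Cell-Growth Inhibitor

The compounds below may be only part of what the source reports. "The series", "measured", "known", "first", "only" and "open" are said of these compounds alone.

Compound 1 `O=C(/C=C/c1cn(-c2ccccc2)nc1-c1ccncc1)c1ccccc1`: 3100 nM
Compound 2 `COc1cc(OC)c(C(=O)/C=C/c2cn(-c3ccccc3)nc2-c2ccncc2)c(OC)c1`: 600 nM

Of the compounds shown here, two sharing one core have been measured in a functional assay on HCT-116 cells (Homo sapiens) for inhibition, read by sulforhodamine B assay, with a stated time of 72 h; a lower number here means a stronger inhibitor, a higher number a weaker inhibitor. Compound 1 gives 3100 nM, while compound 2, which carries three methoxy groups on its benzoyl ring, gives 600 nM. Compound 2 therefore stands as the lower of the two numbers, and its distance from compound 1 lies beyond the scatter of this assay.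

Compound 3 `COc1ccc(C(=O)/C=C/c2cn(-c3ccccc3)nc2-c2ccncc2)c(OC)c1` has not yet been measured. It differs from compound 2 in one place: hydrogen in place of methoxy on an aromatic carbon, so two methoxy groups remain. Since the step from one methoxy-free ring to three methoxy groups lowered the number, removing one of them is expected to move the number part of the way back toward compound 1, a modest step upward. Compound 3 is thus estimated at 1200 nM (range 500 nM to 3000 nM), corresponding to an expected step of a 2.0-fold higher number from compound 2 to compound 3 (0.30 log units; within the scatter).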

Compound 3, half-maximal inhibitory concentration: 4400 nM
For compound 3 the middle estimate is 3.7-fold (0.56 log units) below the measured one; the measured number lies above the stated range.
By their numbers in this assay, from the lowest: compound 2; then compounds 1 and 3 (each within the scatter of the next).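

In this assay, among the compounds shown here, taking away the one methoxy group that sits ortho to a large group and meta to two methoxy groups gives a 7.3-fold higher number from compound 2 to compound 3 (0.87 log units; beyond the scatter), a far larger effect than a single small group might suggest. Compound 3 also cannot be told apart from the methoxy-free ring, with a 1.4-fold higher number from compound 1 to compound 3 (0.15 log units; within the scatter), so the two methoxy groups that remain bring no measurable benefit on their own, and the advantage of compound 2 depends on having this third group in place. Nothing available explains this dependence.

Going by these compounds, it remains open whether this position needs a methoxy group specifically, or whether an ethoxy group, a fluorine atom or an amine would serve there too. Also open, on these data alone, is whether this methoxy group could lower the number without the other two.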